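The source may hold more compounds than are shown below. What is called first, only, known or untested is meant among the compounds shown, and "the series" means these compounds.

Compound 2 `COc1cc(Cl)cc(-c2nn(-c3cccc(NC(=O)Nc4cccc(C(F)(F)F)c4)c3)cc2-c2ccncc2)c1` gives 19% in a functional assay on HCC 2998 cells (Homo sapiens) for inhibition, read by sulforhodamine B assay, with a stated time of 48 h, tested at 10 uM; on this read-out higher numbers stand for a weaker effect at the one concentration tested and lower numbers for a stronger effect. Of the two numbers recorded, compound 1 `COc1cc(Cl)cc(-c2nn(-c3cccc(NC(=O)Nc4ccc(Cl)c(Cl)c4)c3)cc2-c2ccncc2)c1` is nearest to it with 26.7%, and the step of a number 7.7 percentage points lower from compound 1 to compound 2 (within the scatter) lies within the scatter. Compound 3 `COc1cc(Cl)cc(-c2nn(-c3cccc(NC(=O)c4cccc(C(F)(F)F)c4)c3)cc2-c2ccncc2)c1` differs from compound 2 in one place: 3-(trifluoromethyl)phenyl in place of (3-(trifluoromethyl)phenyl)amino on a carbonyl carbon. Among the measured compounds shown here, no measured step touches the carbonyl carbon; the only known step exchanged 3,4-dichlorophenyl for 3-(trifluoromethyl)phenyl on an amide-type nitrogen and stayed within the scatter, so no step beyond the scatter is expected here either. The estimated value for compound 3 is 25%, with a range from 8% to 50%, meaning an expected step of a number 6 percentage points higher from compound 2 to compound 3 (within the scatter).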

Compound 3, a percentage reported as activity, at one concentration (the size of the read-out at that concentration, not a potency): 54.6%
The estimate for compound 3 lay 29.6 percentage points below the measured number; measured number outside the range, above it.
By their numbers in this assay, from the lowest: compounds 2 and 1 (each within the scatter of the next); then compound 3.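

On the carbonyl carbon, the amino nitrogen linking the aryl group matters far more than the earlier swap of aryl groups did: replacing (3-(trifluoromethyl)phenyl)amino with 3-(trifluoromethyl)phenyl gives a number 35.6 percentage points higher from compound 2 to compound 3 (beyond the scatter). Replacing (3,4-dichlorophenyl)amino with the same group gives a number 27.9 percentage points higher from compound 1 to compound 3 (beyond the scatter), so with either aryl group, the change weakens the effect at the one concentration tested. No available evidence explains this loss. Still open, going by these compounds, is whether an oxygen atom or a methylene group in place of that nitrogen would keep the stronger effect.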